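The compounds below may be only part of what the source reports. "The series", "measured", "known", "first", "only" and "open" are said of these compounds alone.

Measured in a functional assay for inhibition, with Rattus norvegicus as the target; a higher number here means a weaker inhibitor, a lower number a stronger inhibitor:
Compound 1 `CC(/N=c1\c(O)c(O)\c1=N/c1cccnc1)C(C)(C)C`: 1950 nM
Compound 2 `CC(/N=c1\c(O)c(O)\c1=N/c1cccnc1O)C(C)(C)C`: > 30000 nM, a limit of the assay
Compound 3 `CC(/N=c1\c(O)c(O)\c1=N/c1ccccc1)C(C)(C)C`: 5400 nM

Of the two actual numbers, compound 3 holds the higher, and the gap is the modest step of a 2.8-fold higher number from compound 1 to compound 3 (0.44 log units; beyond the scatter). Compound 4 `CC(/N=c1\c(O)c(O)\c1=N/c1ccc(C#N)cc1)C(C)(C)C` differs from compound 3 by cyano in place of hydrogen on an aromatic carbon, para to a large group.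

The closest measured change is the large step of an at least 15-fold higher number from compound 1 to compound 2 (1.18 log units; beyond the scatter), but it brings hydroxy, not cyano, and it ends at a limit, so it transfers poorly. The modest step of a 2.8-fold higher number from compound 1 to compound 3 (0.44 log units; beyond the scatter) shows that phenyl carries the higher number of that pair. A modest move toward a lower number is therefore expected, with low confidence, as the estimated step of a 3.0-fold lower number from compound 3 to compound 4 (0.48 log units; beyond the scatter). For compound 4 the expected value is 1800 nM, with an estimated range of 300 nM to 9000 nM.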

Compound 4, half-maximal inhibitory concentration: 520 nM
Compound 4: middle estimate off by 3.5-fold (0.54 log units), on the high side; low and high end bracket the measured number.
By their numbers in this assay, from the lowest: compound 4; then compound 1; then compound 3. At a limit, above all of these: compound 2.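

In this assay, cyano in place of hydrogen on an aromatic carbon, para to a large group, gives a 10-fold lower number from compound 3 to compound 4 (1.02 log units; beyond the scatter) and is the first such replacement shown to lower the number. The only earlier replacement of this kind, hydroxy in compound 2, gives > 30000 nM as a limit of the assay. A substituent at this place on the phenyl ring can therefore lower the number substantially.

No measurement shown accounts for this step. On these data alone, whether the step is specific to cyano stays open, as an amine or a carboxylic acid at the same place would test.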